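A few compounds are considered here, and "the series" means these few. Any claim that something is new, unique, unknown or untested is made for them only; others in the source may bear on it.

Measured so far in a functional assay on BHK-21 cells (Mesocricetus auratus) for cytotoxicity, read by MTT assay; a higher number here means that more compound is tolerated, a lower number that less compound is tolerated:
- compound 1 `O=C(c1ccccc1)N1N=C(c2cccs2)CC1c1ccc(Br)cc1`: > 300000 nM (a limit)
- compound 2 `COc1ccc(C2CC(c3cccs3)=NN2C(=O)c2ccccc2)cc1`: > 300000 nM (a limit)

Compound 2 stands at > 300000 nM, which is a limit of the assay and not a number. Going by the values given here, the only measured step that bears on the next change is a step that the two limits leave unreadable from compound 1 to compound 2, with methoxy in place of bromo on an aromatic carbon. Among the compounds with values here, the sole evidence on it is the limit of > 300000 nM in this assay, at which 2 of the 2 values shown sit.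

Compound 3 `O=C(c1ccccc1)N1N=C(c2cccs2)CC1c1ccc(F)cc1` carries fluoro in place of methoxy on an aromatic carbon, para to a large group: fluoro in place of methoxy on an aromatic carbon. Neither measured compound gives a number, so no size can be carried over from the measured step. No step beyond the scatter is expected in this assay, and another limit is the likeliest report. The expected change is a number no higher from compound 2 to compound 3 (the limit leaves the size open). For compound 3 the estimate is 300000 nM, with an expected range of 150000 nM to 600000 nM.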

Compound 3, half-maximal cytotoxic concentration: 100000 nM
Beside the measured number, compound 3's estimate is 3.0-fold (0.48 log units) above it; measured number below the stated range.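

Position note: on the aromatic carbon para to a large group, the series now gives a readable change in this assay, where the earlier pair gave none. Fluoro in place of methoxy gives an at least 3.0-fold lower number from compound 2 to compound 3 (0.47 log units; beyond the scatter), and fluoro in place of bromo at the same place gives an at least 3.0-fold lower number from compound 1 to compound 3 (0.47 log units; beyond the scatter), so this position is not silent in this assay and the outcome depends on the group placed there. The step between the two compounds at the limit cannot be read, and both new steps are minimum sizes with their full extent open: the limit of > 300000 nM in this assay, at which 2 of the 3 values shown sit.

Still open, as far as these compounds go, is whether the lower number is particular to fluoro or also appears with other groups at this place, such as chloro, a nitrile, an amine or a carboxylic acid. Also open, from the compounds shown here alone, is whether hydrogen at this place would sit with compound 3 or with the compounds at the limit.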